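Mirror-image pair in a GPR39 maximal-response series

This account rests on a few compounds, and the source may have more. Where it says the series, first, only, none or still open, it means among the compounds named here.

Compound 1 `N#Cc1ccc(N2CCN(Cc3cn4cc(Cl)ccc4n3)CC2)nc1`: 76%
Compound 2 `CCc1nc(CN2C[C@H](C(=O)NCc3ccccc3Cl)[C@@H](c3cccnc3)C2)c[nH]1`: 66%

In an assay on CHO-K1 cells for agonist activity at G-protein coupled receptor 39 (Homo sapiens), read by FLIPR and calcium flux, with a stated time of 1 h (on this read-out higher numbers stand for larger maximal responses and lower numbers for smaller maximal responses), compound 1 gives 76% and compound 2 gives 66%. Compound 2 holds the lower of the two numbers, but its gap to compound 1 lies within the usual scatter, so no order between the two is claimed. Compound 3 `CCc1nc(CN2C[C@@H](C(=O)NCc3ccccc3Cl)[C@H](c3cccnc3)C2)c[nH]1` is the mirror image of compound 2: the two compounds have the same atoms and bonds and differ only in configuration as drawn: 2 of 2 stereo elements differ (all stereocentres are inverted: mirror images); a stereocentre at a saturated ring carbon is drawn R in compound 2 and S in compound 3; a stereocentre at a saturated ring carbon is drawn S in compound 2 and R in compound 3. For the measured compounds named here, no step between measured compounds involves a change of configuration, so the size of this step is unknown from the data. The expectation is a downward step in this assay, with wide uncertainty. Compound 3 is estimated at 45%, range 10% to 75%, an expected step of a number 21 percentage points lower from compound 2 to compound 3 (beyond the scatter).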

Compound 3, largest response reached (reported as efficacy), in percent of the reference or control that the assay uses in the G-protein coupled receptor 39 assay: 74%
The estimate for compound 3 lay 29 percentage points below the measured number, within the range that was stated.
By their numbers in the G-protein coupled receptor 39 assay, from the lowest: compounds 2, 3 and 1 (each within the scatter of the next).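

Inverting both stereocentres gives, in the G-protein coupled receptor 39 assay, a number 8 percentage points higher from compound 2 to compound 3 (within the scatter), so this first configuration step in the series does not separate the mirror images on maximal response. In a physicochemical assay for permeability (on this read-out higher numbers stand for higher permeability and lower numbers for lower permeability), compound 2 gives 1.2 10^-6 cm/s and compound 3 gives 0.8 10^-6 cm/s, which is a 1.5-fold lower number from compound 2 to compound 3 (0.18 log units; within the scatter). Any difference within this pair can rest on one change only: the fact that compounds 2 and 3 differ only in the configuration as drawn

Open, as far as these compounds go, is the outcome of inverting just one of the two stereocentres. Also open, from the compounds shown here alone, is whether configuration stays this silent when a longer chain replaces the ethyl group or a methoxy group replaces the chlorine.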